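The source may hold more compounds than are shown below. What is called first, only, known or untested is meant among the compounds shown, and "the series" means these compounds.

In an ADME assay on MDCK-II cells (Canis lupus familiaris) for permeability (on this read-out higher numbers stand for higher permeability and lower numbers for lower permeability), compound 1 `Nc1nc2c(s1)CC[C@H]2C(=O)Nc1ccc(C[C@@H]2CC[C@H]([C@H](O)c3cccnc3)N2)cc1` gives < 1 10^-6 cm/s, which is a limit and not a number. Within the data shown here, compound 2 `Cc1nc2c(s1)CC[C@H]2C(=O)Nc1ccc(C[C@@H]2CC[C@H]([C@H](O)c3ccccc3)N2)cc1` gives 26 10^-6 cm/s, the only true number available in this assay, so it is the sole numerical reference for what follows.

Compound 3 `Cc1nc2c(s1)CC[C@H]2C(=O)Nc1ccc(C[C@@H]2CC[C@H]([C@H](O)c3cccnc3)N2)cc1` comes from compound 2 through a single change: pyridin-3-yl in place of phenyl on a saturated chain carbon bound to an oxygen on a saturated carbon and a saturated ring carbon. This puts pyridin-3-yl in place of phenyl on a saturated chain carbon bound to an oxygen on a saturated carbon and a saturated ring carbon. Among the measured compounds shown here, no pair of measured compounds differs in one place only, so this change has no direct precedent. For the measured compounds named here, the one hint is compound 1, which also carries pyridin-3-yl and whose < 1 10^-6 cm/s is again a limit. Compound 1 differs from compound 3 elsewhere as well, so the hint is weak. A downward move in this assay is therefore expected, of modest size and only a little beyond the usual scatter. The expected step is a 2.6-fold lower number from compound 2 to compound 3 (0.41 log units; beyond the scatter). For compound 3 the estimated value is 10 10^-6 cm/s, with an expected range from 3 10^-6 cm/s to 24 10^-6 cm/s.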

Compound 3, apparent permeability: 17 10^-6 cm/s
Compound 3: the middle estimate sits 1.7-fold (0.23 log units) below what was measured; the measured number falls inside the stated range.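

In this assay, pyridin-3-yl in place of phenyl on a saturated chain carbon bound to an oxygen on a saturated carbon and a saturated ring carbon gives a 1.5-fold lower number from compound 2 to compound 3 (0.18 log units; within the scatter), so the new ring nitrogen at this position brings no change that can be told from scatter. The large step instead comes with methyl in place of amino on an aromatic carbon, with pyridin-3-yl present on both sides of the comparison: an at least 17-fold higher number from compound 1 to compound 3 (1.23 log units; beyond the scatter). Compound 1 gives < 1 10^-6 cm/s, which is a limit and not a number, so the step from it fixes only a lower bound on the size of this change: the limit of < 1 10^-6 cm/s in this assay, at which 1 of the 3 values shown sits.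

On these data alone, whether the tolerance seen at this position extends to other rings, such as pyridin-4-yl or a pyrimidine, remains open, since only phenyl and pyridin-3-yl appear there. As far as these compounds go, it is also open whether the exchange of amino and methyl on the aromatic carbon has the same size with phenyl at the other position, and how an ethyl group or a hydroxymethyl group on that aromatic carbon would read in this assay.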